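Tert-Butoxy in Place of Cyclopropyl on a Carbonyl Carbon

This account rests on a few compounds, and the source may have more. Where it says the series, first, only, none or still open, it means among the compounds named here.

Measured in a functional assay on BXPC-3 cells (Homo sapiens) for inhibition, read by MTT assay, with a stated time of 7 days; a higher number here means a weaker inhibitor, a lower number a stronger inhibitor:
- Compound 1 `CCOC(=O)[C@@H]1CCCN(S(=O)(=O)c2ccc(S(=O)(=O)N3CCOCC3)cc2)C1` gives 23400 nM
- Compound 2 `CCN(CC)S(=O)(=O)c1ccc(S(=O)(=O)N2CCC[C@@H](C(=O)NC3CN(C(=O)C4CC4)C3)C2)cc1` gives 18500 nM

Compound 2, at 18500 nM, stands level with compound 1, at 23400 nM, since these two values lie within the usual scatter of repeated measurements. The two compounds differ in more than one place, so this pair does not show what any single change does.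

The next compound is compound 3 `CCN(CC)S(=O)(=O)c1ccc(S(=O)(=O)N2CCC[C@@H](C(=O)NC3CN(C(=O)OC(C)(C)C)C3)C2)cc1`. It has tert-butoxy in place of cyclopropyl on a carbonyl carbon, and the rest of compound 2 stays the same: tert-butoxy in place of cyclopropyl on a carbonyl carbon.

Within the data shown here, no measured pair shows this change or any other single change, so the expectation is only a cautious one. With compound 2 at 18500 nM as the starting point, no step beyond the scatter is expected in this assay. The estimated step of a 1.2-fold lower number from compound 2 to compound 3 (0.09 log units; within the scatter) is small, with a slight lean towards a lower number. For compound 3 the estimated value is 15000 nM, with an expected range of 6000 nM to 35000 nM.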

Compound 3, half-maximal inhibitory concentration: 1800 nM
Beside the measured number, compound 3's estimate is 8.3-fold (0.92 log units) above it; measured number outside the range, below it.
By their numbers in this assay, from the lowest: compound 3; then compounds 2 and 1 (each within the scatter of the next).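

In this assay, among these compounds, this is the first single change that can be read, and it is a large one: a 10-fold lower number from compound 2 to compound 3 (1.01 log units; beyond the scatter). The earlier compounds shown here differed in more than one place and could show no such effect, whereas here only the group on the carbonyl carbon differs, so this position clearly matters for the number in this assay. No measurement at hand explains why tert-butoxy gives a lower number here than cyclopropyl.

The change alters several things at once: a three-membered ring of carbon leaves, and an open group with one oxygen and more carbon enters, so the pair cannot say which of these differences counts. A tert-butyl group set directly on the carbonyl carbon, without the oxygen, would begin to separate those parts, as would a smaller methoxy group with the oxygen kept, while a free amine in place of the whole tert-butoxycarbonyl group would test whether anything on this nitrogen is needed at all.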